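Hydroxyphenyl hydrazones of a shared benzofuran-like core: compound 4

The source may hold more compounds than are shown below. What is called first, only, known or untested is meant among the compounds shown, and "the series" means these compounds.

Measured compounds:
Compound 1 `Cc1c(C(=O)N/N=C\c2c(O)cccc2Cl)oc2cccc(O)c12` gives 18700 nM in a functional assay on PC-3 cells (Homo sapiens) for inhibition; a higher number here means a weaker inhibitor, a lower number a stronger inhibitor.
Compound 2 `Cc1c(C(=O)N/N=C\c2ccccc2F)oc2cccc(O)c12` gives only a limit of the assay, >= 40000 nM.
Compound 3 `Cc1c(C(=O)N/N=C\c2ccc(Br)cc2O)oc2cccc(O)c12` gives 2050 nM.

Compound 1 holds the highest of the two numbers obtained; its nearest neighbour is compound 3, reached by a 9.1-fold lower number from compound 1 to compound 3 (0.96 log units; beyond the scatter). The value of compound 2 is a limit, not a number, as noted at the limit of >= 40000 nM in this assay, at which 1 of the 3 values shown sits.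

Compound 4 `Cc1c(C(=O)N/N=C\c2ccc(O)cc2O)oc2cccc(O)c12` differs from compound 1 as follows: 2,4-dihydroxyphenyl in place of 2-chloro-6-hydroxyphenyl on a carbon with a double bond to nitrogen. The step of a 9.1-fold lower number from compound 1 to compound 3 (0.96 log units; beyond the scatter) bears most directly on this change, since it too keeps a hydroxyl on the aryl group while adding a substituent at the 4-position; the step of an at least 2.1-fold higher number from compound 1 to compound 2 (0.33 log units; beyond the scatter) points the other way. A modest fall in the number is therefore expected for compound 4, about a 3.1-fold lower number from compound 1 to compound 4 (0.49 log units; beyond the scatter). Compound 4 is estimated at 6000 nM, between 1500 nM and 25000 nM.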

Compound 4, half-maximal inhibitory concentration: 14800 nM
Compound 4: middle estimate off by 2.5-fold (0.39 log units), on the low side, and the stated range covers the measured number.
By their numbers in this assay, from the lowest: compound 3; then compounds 4 and 1 (each within the scatter of the next). At a limit, above all of these: compound 2.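

In this assay, hydroxy in place of bromo on an aromatic carbon gives a 7.2-fold higher number from compound 3 to compound 4 (0.86 log units; beyond the scatter), so the gain seen with 4-bromo-2-hydroxyphenyl does not carry over to 2,4-dihydroxyphenyl. Against 2-chloro-6-hydroxyphenyl, 2,4-dihydroxyphenyl brings no change beyond the scatter, with a 1.3-fold lower number from compound 1 to compound 4 (0.10 log units; within the scatter). Compound 2 is known only as a limit of the assay, so its step is a bound, an at least 2.7-fold lower number from compound 2 to compound 4 (0.43 log units; beyond the scatter), which still sets 2,4-dihydroxyphenyl apart from 2-fluorophenyl: the limit of >= 40000 nM in this assay, at which 1 of the 4 values shown sits.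

The compounds shown leave open whether a methoxy group, an amine or iodo in place of bromo would keep the number of compound 3.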